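A few compounds are considered here, and "the series" means these few. Any claim that something is new, unique, unknown or untested is made for them only; others in the source may bear on it.

Measured compounds:
compound 1 `C=C1CCCC(C)(C)C1CC[C@]1(C)CC[C@@H]([C@@H](C)C(=O)O)OO1` — > 10000 nM
compound 2 `C=C1CCCC(C)(C)C1CC[C@]1(C)CC[C@H]([C@@H](C)C(=O)OC)OO1` — 4760 nM
compound 3 `C=C1CCC[C@H]2[C@](C)(CC[C@]3(C)CC[C@@H]([C@@H](C)C(=O)O)OO3)[C@@H](C)CC[C@]12C` — 2720 nM

The study follows the move from compound 1 to compound 4 in a functional assay on OVCAR-5 cells (Homo sapiens) for inhibition; a lower number here means a stronger inhibitor of growth, a higher number a weaker inhibitor of growth. In this assay compound 1 gives > 10000 nM, which is a limit of the assay and not a number. Its position among the three measured values is therefore the weakest one that can be stated, as the limit of > 10000 nM in this assay, at which 1 of the 3 values shown sits, shows; the other two compounds return actual numbers, with compound 2 giving 4760 nM and compound 3 giving 2720 nM. Compound 4 `C=C1CCCC(C)(C)C1CC[C@@]1(C)CC[C@H]([C@@H](C)C(=O)O)OO1` keeps every atom and bond of compound 1: the two compounds have the same atoms and bonds; at least one stereo element is drawn with a configuration in one of them and without one in the other: 2 of 4 stereo elements differ; a stereocentre at a saturated ring carbon is drawn R in compound 1 and S in compound 4; a stereocentre at a saturated ring carbon is drawn S in compound 1 and R in compound 4. Among the measured compounds shown here, no pair of measured compounds differs in a single place, so there is no measured step to lean on, and the effect of inverting two ring stereocentres has to be guessed. A change from a limit to a measurable number would be needed for any real step to appear, and the author expects at most a modest gain, with the step from compound 1 to compound 4 estimated at an at least 1.4-fold lower number from compound 1 to compound 4 (0.15 log units; that floor lies within the scatter). For compound 4 the estimated value in this assay is 7000 nM, with a range from 2500 nM to 20000 nM.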

Compound 4, concentration for 50% growth inhibition: > 12500 nM
Compound 4 gave a limit, no number; the forecaster's own chance of this, stated with the estimate: 45%; at least 1.7-fold (0.25 log units) between middle value and limit.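

No step can be read between compound 1 and compound 4 in this assay, since each of the two compounds gives only a limit of the assay and not a number. The compounds shown leave open whether inverting the two ring stereocentres changes growth inhibition in this assay at all, and if it does, in which direction and by how much.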